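A few compounds are considered here, and "the series" means these few. Any claim that something is new, unique, unknown or untested is made for them only; others in the source may bear on it.

In an ADME assay on HEK-293T cells (Homo sapiens) for cytotoxicity, read by luminescence, with a stated time of 24 h (on this read-out higher numbers stand for lower toxicity in this test and lower numbers for higher toxicity in this test), compound 1 (`CCOC(=O)c1cc2sccc2n1Cc1ccc(OC)cc1`) gives > 100000 nM, a limit of the assay. Compound 2 (`COc1ccc(Cn2c(C(=O)N3CCC(C(N)=O)CC3)cc3sccc32)cc1`) gives > 100000 nM, also a limit. Compound 3 (`COc1ccc(Cn2c(C(=O)N3CCC(C(=O)NC(C)c4ccccc4)CC3)cc3sccc32)cc1`) gives > 100000 nM, again a limit, so it stands only at that limit and has no number.

The change to compound 4 (`COc1ccc(Cn2c(C(=O)N3CCC(C(=O)NCC4CC4)CC3)cc3sccc32)cc1`) is cyclopropylmethyl in place of 1-phenylethyl on an amide-type nitrogen.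

Within the data shown here, two measured steps bear on it: a step that the two limits leave unreadable from compound 1 to compound 2, and the closer one on the same nitrogen, a step that the two limits leave unreadable from compound 2 to compound 3. Neither has a readable size. What they do show is the limit of > 100000 nM in this assay, at which 3 of the 3 values shown sit.

No step beyond the scatter is therefore expected in this assay. The expected change is a number no higher from compound 3 to compound 4 (the limit leaves the size open). For compound 4 the estimate is 100000 nM, with an expected range of 50000 nM to 200000 nM.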

Compound 4, half-maximal cytotoxic concentration: 24600 nM
The estimate for compound 4 lay 4.1-fold (0.61 log units) above the measured number; measured number below the stated range.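

In this assay the group on the amide-type nitrogen can move the read-out: cyclopropylmethyl in place of 1-phenylethyl gives an at least 4.0-fold lower number from compound 3 to compound 4 (0.60 log units; beyond the scatter). Cyclopropylmethyl in place of hydrogen on the same nitrogen gives an at least 4.0-fold lower number from compound 2 to compound 4 (0.60 log units; beyond the scatter). Compound 4 is the only compound shown with a number rather than a limit: the limit of > 100000 nM in this assay, at which 3 of the 4 values shown sit.

As far as these compounds go, the full size of both steps stays open, since compound 2 and compound 3 stand only at a limit. Also open, from the compounds shown here alone, is whether the three-membered ring itself matters, which a butyl chain or a benzyl group on this nitrogen would test.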